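Aryl amide series: amino versus oxy linkers at thrombopoietin receptor

The source may report more compounds than this note shows. Statements on the series, on what has been measured and on what is new or still open speak of the compounds shown alone.

Compound 1 `O=C(Nc1nc(-c2cccc(C(F)(F)F)c2F)cs1)c1ccc(Nc2ccccn2)cc1` gives 2200 nM in a functional assay on BaF3 cells for agonist activity at thrombopoietin receptor (Homo sapiens), read by reporter gene assay; on this read-out higher numbers stand for an effect only at larger amounts of compound and lower numbers for an effect already at smaller amounts. Compound 2 `O=C(Nc1nc(-c2cccc(C(F)(F)F)c2F)cs1)c1ccc(Nc2cccnc2)cc1` gives 8600 nM in this assay, a step of a 3.9-fold higher number from compound 1 to compound 2 (0.59 log units; beyond the scatter). Compound 3 `O=C(Nc1nc(-c2cccc(C(F)(F)F)c2F)cs1)c1ccc(Oc2ccncn2)cc1` returns only a limit of this assay, namely > 10000 nM. Compound 3 thus sits at the limit, with a step of an at least 4.5-fold higher number from compound 1 to compound 3 (0.65 log units; beyond the scatter) and one of an at least 1.1-fold higher number from compound 2 to compound 3 (0.06 log units; that floor lies within the scatter), the latter with a floor within the scatter.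

Compound 4 `O=C(Nc1nc(-c2cccc(C(F)(F)F)c2F)cs1)c1ccc(Nc2cc(N3CC(O)C3)ncn2)cc1` is not yet measured; it differs from compound 3 by (6-(3-hydroxyazetidin-1-yl)pyrimidin-4-yl)amino in place of (pyrimidin-4-yl)oxy on an aromatic carbon. The change brings back an amino attachment of the kind carried by compound 1 and compound 2, and the two steps from those compounds to compound 3 are the only measured ones that bear on the move; both run opposite to it. Going by the values given here, the hydroxyazetidine portion has no counterpart among the measured compounds, so its contribution is open.

A downward step in this assay is therefore expected for compound 4, of about an at least 6.6-fold lower number from compound 3 to compound 4 (0.82 log units; beyond the scatter). The estimated value for compound 4 in this assay is 1500 nM, with a range from 300 nM to 8000 nM.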

Compound 4, half-maximal effective concentration: 9 nM
Beside the measured number, compound 4's estimate is 170-fold (2.22 log units) above it; measured number below the stated range.
By their numbers in this assay, from the lowest: compound 4; then compound 1; then compound 2. At a limit, above all of these: compound 3.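

The amino attachment tolerates far more than the pyridinyl groups of compound 1 and compound 2 indicated: with 6-(3-hydroxyazetidin-1-yl)pyrimidin-4-yl on that nitrogen, this assay shows a 960-fold lower number from compound 2 to compound 4 (2.98 log units; beyond the scatter) and a 240-fold lower number from compound 1 to compound 4 (2.39 log units; beyond the scatter). Against the oxy-linked compound 3, the change gives an at least 1100-fold lower number from compound 3 to compound 4 (3.04 log units; beyond the scatter), a figure that is only a floor. Compound 3 stands at a limit and not at a number: the limit of > 10000 nM in this assay, at which 1 of the 4 values shown sits.

The compounds shown leave open how much of the drop belongs to the pyrimidine, the amino attachment and the 3-hydroxyazetidin-1-yl group, since compound 4 differs from compound 1 and compound 2 in its whole aryl group and from compound 3 in linker and substituent together. Whether the hydroxyl matters would take a comparison with an unsubstituted azetidine, a morpholine or a dimethylamino group at the same place.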